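Dihydrofolate reductase inhibition: dichlorophenyl trimmed to chlorophenyl

The source may hold more compounds than are shown below. What is called first, only, known or untested is meant among the compounds shown, and "the series" means these compounds.

compound 1 `COc1ccc(OCCCON2C(N)=NC(N)=NC23CCOCC3)cc1` — "not determined" (no result reported)
compound 2 `NC1=NC2(CCOCC2)N(OCCCOc2cccc(Cl)c2Cl)C(N)=N1` — 89.8%

Compound 1 `COc1ccc(OCCCON2C(N)=NC(N)=NC23CCOCC3)cc1` gives "not determined" (no result reported) in an assay on isolated protein for inhibition of Dihydrofolate reductase (Homo sapiens), read by spectrophotometry, using NADPH, with stated times of 5 s and 6 min, tested at 50 uM (on this read-out lower numbers stand for a weaker effect and higher numbers for a stronger effect at the one concentration tested), so it has no result there. Among the compounds with values here, compound 2 `NC1=NC2(CCOCC2)N(OCCCOc2cccc(Cl)c2Cl)C(N)=N1` gives 89.8% in this assay and stands as the only number available, with compound 1 carrying no number. Compound 3 `NC1=NC2(CCOCC2)N(OCCCOc2ccccc2Cl)C(N)=N1` differs from compound 2 by hydrogen in place of chloro on an aromatic carbon, a chloro removed from an aromatic carbon that sits ortho to a chloro group. Within the data shown here, no step between measured compounds is known, so the weight of a single chloro cannot be read from the series itself. The expected step of a number 9.8 percentage points lower from compound 2 to compound 3 (within the scatter) is a modest loss, likely within the usual scatter. Compound 3 is expected to give 80%, in the range 60% to 95%.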

Compound 3, a percentage reported as inhibition, at one concentration (the size of the read-out at that concentration, not a potency): 88.2%
The estimate for compound 3 lay 8.2 percentage points below the measured number; measured number inside the range.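

In this assay, within the data shown here, the step of a number 1.6 percentage points lower from compound 2 to compound 3 (within the scatter) gives the first reading for this position. Among these compounds, with hydrogen in place of chloro, 2,3-dichlorophenyl to 2-chlorophenyl is a change that stays within the scatter, so the second chloro is not required for the inhibition seen at the one concentration tested, and that read-out gives no potency for either compound. No measurement at hand accounts for this result.

Still open, going by these compounds, is whether an amine or a carboxylic acid at this place would read the same, and what removing the remaining chloro would do.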